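This account rests on a few compounds, and the source may have more. Where it says the series, first, only, none or still open, it means among the compounds named here.

Measured in a functional assay on MCF7 cells (Homo sapiens), read by MTT assay, with a stated time of 48 h; on this read-out higher numbers stand for weaker inhibition and lower numbers for stronger inhibition:

Compound 1 `CCN(CC)CCNC(=O)c1ccc(C(CC)(CC)c2ccc(OCC(O)C(C)(C)C)c(C)c2)n1CC`: 690 nM
Compound 2 `CCn1c(C(=O)NCCN(C)C)ccc1C(CC)(CC)c1ccc(OCC(O)C(C)(C)C)c(C)c1`: 660 nM

In this assay, within the data shown here, compound 2 gives 660 nM and stands level with its only measured neighbour, compound 1, at 690 nM. The a 1.0-fold lower number from compound 1 to compound 2 (0.02 log units; within the scatter) shows that the two cannot be separated on these numbers.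

Compound 3 `CCn1c(C(=O)NCCCN(C)C)ccc1C(CC)(CC)c1ccc(OCC(O)C(C)(C)C)c(C)c1` has not yet been measured. It differs from compound 2 in one place: (dimethylamino)methyl in place of dimethylamino on a saturated chain carbon, two bonds along the chain from an amide-type nitrogen. Put another way, 2-(dimethylamino)ethyl gives way to 3-(dimethylamino)propyl on the amide-type nitrogen's side of the molecule, with the dimethylamino end kept.

Among the measured compounds shown here, only one measured step bears on this change. The a 1.0-fold lower number from compound 1 to compound 2 (0.02 log units; within the scatter) alters the same end of the chain, but it swaps the substituents on the amine and leaves the chain length untouched. For the measured compounds named here, no measured pair tests a longer chain, so this evidence is indirect and the range must stay wide. With nothing pointing either way, no shift beyond the scatter is expected, and the expected change is a 1.0-fold lower number from compound 2 to compound 3 (0.01 log units; within the scatter).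

The estimated value for compound 3 is 650 nM, with an expected range from 280 nM to 1500 nM.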

Compound 3, half-maximal inhibitory concentration: 490 nM
Compound 3: middle estimate off by 1.3-fold (0.12 log units), on the high side, and the stated range covers the measured number.
By their numbers in this assay, from the lowest: compounds 3, 2 and 1 (each within the scatter of the next).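

Compound 3 is the first of these compounds to vary the chain length rather than the groups on the terminal amine. With 3-(dimethylamino)propyl in place of 2-(dimethylamino)ethyl, this assay gives a 1.3-fold lower number from compound 2 to compound 3 (0.13 log units; within the scatter), and the step that alters both the chain length and the amine groups gives a 1.4-fold lower number from compound 1 to compound 3 (0.15 log units; within the scatter), so neither change separates the compounds, and all three stand level on these numbers. Nothing in the data shown offers an explanation for these values.

The three compounds therefore show only that this end of the molecule accepts these particular chain and amine combinations, and they say nothing about a longer chain such as 4-(dimethylamino)butyl or about 3-(diethylamino)propyl, which would combine the two variations already seen. On these data alone, it also remains open whether the numbers would stay level with a different kind of group at the chain end, such as a primary amine, a hydroxyl or a carboxylic acid in place of the dimethylamino group.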